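The compounds below may be only part of what the source reports. "The series", "measured", "known", "first", "only" and "open" are said of these compounds alone.

Measured so far:
compound 1, `Cc1noc(C)c1NC(=O)N1CCC(c2nc(-c3ccc4ccccc4n3)no2)CC1`, 3000 nM
compound 2, `Cc1ccccc1NC(=O)N1CCC(c2nc(-c3ccc4ccccc4n3)no2)CC1`, 440 nM
compound 3, `O=C(Nc1ncccc1Cl)N1CCC(c2nc(-c3ccc4ccccc4n3)no2)CC1`, 2800 nM

All three share one core and differ only in the group attached to an amide-type nitrogen. In a functional assay on Shh Light II cells (Mus musculus) for inhibition, read by a luciferase reporter (a higher number here means a weaker inhibitor, a lower number a stronger inhibitor), compound 1 gives the highest of the three numbers. Its nearest neighbour is compound 3, which sits within the scatter (a 1.1-fold lower number from compound 1 to compound 3 (0.03 log units; within the scatter)), while compound 2 stands clearly apart (a 6.8-fold lower number from compound 1 to compound 2 (0.83 log units; beyond the scatter)).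

Compound 4, `O=C(Nc1cccnc1Cl)N1CCC(c2nc(-c3ccc4ccccc4n3)no2)CC1`, is not yet measured. It differs from compound 1 in one place: 2-chloropyridin-3-yl in place of 3,5-dimethyl-1,2-oxazol-4-yl on an amide-type nitrogen. For the measured compounds named here, two measured steps bear on this change. The step to a six-membered aromatic ring carrying a methyl group, from compound 1 to compound 2, was a modest drop in the number; the step to a six-membered ring carrying a chlorine and a ring nitrogen, from compound 1 to compound 3, stayed within the scatter. Compound 4 carries a chlorine and a ring nitrogen like compound 3, only arranged differently on the ring, so the outcome for compound 4 is expected to lie between those two cases, with a small to modest fall in the number and wide uncertainty. Compound 4 is therefore expected to give 1500 nM, within 500 nM to 4500 nM, an expected step of a 2.0-fold lower number from compound 1 to compound 4 (0.30 log units; within the scatter).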

Compound 4, half-maximal inhibitory concentration: 1600 nM
Beside the measured number, compound 4's estimate is 1.1-fold (0.03 log units) below it; the measured number falls inside the stated range.
By their numbers in this assay, from the lowest: compound 2; then compounds 4, 3 and 1 (each within the scatter of the next).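

Compounds 3 and 4 carry the same chlorine and ring nitrogen, arranged differently on a six-membered aromatic ring, and in this assay this rearrangement gives a step within the scatter (a 1.8-fold lower number from compound 3 to compound 4 (0.24 log units; within the scatter)), so it cannot be read as a real difference. The 2-chloropyridin-3-yl group also cannot be told apart from the 3,5-dimethyl-1,2-oxazol-4-yl group (a 1.9-fold lower number from compound 1 to compound 4 (0.27 log units; within the scatter)), even though one is a six-membered ring and the other a five-membered ring. The 2-methylphenyl group stands apart from this new group as well (a 3.6-fold higher number from compound 2 to compound 4 (0.56 log units; beyond the scatter)), so among these four compounds, the one group with no hetero atom in its ring gives the lowest number, and no compound shown goes against that.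

No measurement shown here explains these differences. The compounds shown also leave open whether the methyl group or the absence of a ring nitrogen sets compound 2 apart, a question that a 2-chlorophenyl or a 2-methylpyridin-3-yl group on the same amide-type nitrogen could help to separate.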